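Amino for Methoxy at the Cytotoxicity Limit

The source may report more compounds than this note shows. Statements on the series, on what has been measured and on what is new or still open speak of the compounds shown alone.

Compound 2 `COC(=O)c1c(-c2ccc(OC)cc2)oc2ccccc2c1=O` is the starting point. In a functional assay on A549 cells (Homo sapiens) for cytotoxicity, read by MTT assay, with a stated time of 6 days (on this read-out higher numbers stand for an effect only at larger amounts of compound and lower numbers for an effect already at smaller amounts), compound 2 gives > 25 ug/mL, which is a limit of the assay rather than a number. The other measured compounds sit in the same place. Compound 1 `COC(=O)c1c(-c2cc(OC)cc(OC)c2)oc2ccccc2c1=O` gives > 25 ug/mL in this assay, again a limit. Compound 3 `COC(=O)c1c(-c2ccc([N+](=O)[O-])cc2)oc2ccccc2c1=O` gives > 25 ug/mL in this assay, also a limit. Among the measured compounds shown here, the one step between measured compounds, a step that the two limits leave unreadable from compound 2 to compound 3, is therefore of unreadable size, because the limit of > 25 ug/mL in this assay, at which 3 of the 3 values shown sit, places every value shown at the limit itself.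

Compound 4 `COC(=O)c1c(-c2ccc(N)cc2)oc2ccccc2c1=O` is not yet measured; it differs from compound 2 as follows: amino in place of methoxy on an aromatic carbon. For the measured compounds named here, no measured step bears directly on this change, and the one step there is, a step that the two limits leave unreadable from compound 2 to compound 3, cannot be sized. No step beyond the scatter is therefore expected in this assay, in either direction, and the most likely outcome is another limit. Compound 4 is expected to give about 40 ug/mL, within 12 ug/mL to 150 ug/mL, in this assay. That estimate means an expected step that the limit leaves unreadable from compound 2 to compound 4.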

Compound 4, concentration for half-maximal effect: > 25 ug/mL
Compound 4: a limit, no number (the forecaster's own chance of this, stated with the estimate: 75%); the middle value lies beyond the limit too.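

In this assay compound 4 gives > 25 ug/mL, a limit and not a number. Its steps from compound 2 and compound 3 cannot be read, because all the compounds share one limit: the limit of > 25 ug/mL in this assay, at which 4 of the 4 values shown sit.

The compounds shown leave open how they rank against one another in cytotoxicity.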